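The source may report more compounds than this note shows. Statements on the series, on what has been measured and on what is new or still open speak of the compounds shown alone.

In a functional assay on HeLa S3 cells (Homo sapiens) for antiproliferative activity, read by XTT assay, with a stated time of 72 h (a higher number here means a weaker inhibitor, a lower number a stronger inhibitor), compound 1 `CSc1ncnc2c1c(-c1ccoc1)cn2[C@@H]1O[C@H](CO)[C@@H](O)[C@H]1O` gives 5390 nM. Compound 2 `Cc1ncnc2c1c(-c1ccoc1)cn2[C@@H]1O[C@H](CO)[C@@H](O)[C@H]1O` is reported only as a limit, > 20000 nM. Compound 3 `C#Cc1cn([C@@H]2O[C@H](CO)[C@@H](O)[C@H]2O)c2ncnc(C)c12` carries ethynyl in place of furan-3-yl on an aromatic carbon. Among the measured compounds shown here, the only measured step, an at least 3.7-fold higher number from compound 1 to compound 2 (0.56 log units; beyond the scatter), is a different change, so it sets no direct size for this one. A modest move towards a lower number in this assay is expected, although the result may well remain at the limit. The expected change is an at least 1.3-fold lower number from compound 2 to compound 3 (0.12 log units; that floor lies within the scatter). For compound 3 the estimated value is 15000 nM, with an expected range of 2000 nM to 40000 nM.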

Compound 3, half-maximal inhibitory concentration: 14700 nM
The estimate for compound 3 lay 1.0-fold (0.01 log units) above the measured number, within the range that was stated.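

The earlier compounds shown here all carried furan-3-yl at this position, two ring bonds from the ring nitrogen; with ethynyl there, compound 3 gives a readable value in this assay, 14700 nM. The change to ethynyl gives an at least 1.3-fold lower number from compound 2 to compound 3 (0.13 log units; that floor lies within the scatter), so the printed floor alone does not separate the two compounds. Compound 2 is known here only as a limit, which leaves the true size of the step unknown: the limit of > 20000 nM in this assay, at which 1 of the 3 values shown sits.

On these data alone, it remains open how ethynyl would read with methylsulfanyl in place of methyl on the shared core. Also open, as far as these compounds go, is how an amine or a longer alkynyl chain would read at this position.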